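Swapping an aryl group for an anilide on the shared core

This account rests on a few compounds, and the source may have more. Where it says the series, first, only, none or still open, it means among the compounds named here.

Measured compounds:
compound 1, `Cc1nn(-c2ncnc3nc[nH]c23)c2c1C(c1ccc(OC(C)C)cc1)CC(=O)N2`, 18 nM
compound 2, `CCC(C(=O)NC1CC(=O)Nc2c1c(C)nn2-c1ncnc2nc[nH]c12)c1ccccc1`, 5 nM
compound 3, `C=CCN1c2c(n(C)c(=O)n(C)c2=O)NC1N/N=C/c1ccc(O)cc1O`, 340 nM

These values come from a functional assay on HEK293 cells for agonist activity at G-protein coupled receptor 39 (Homo sapiens), read by scintillation proximity assay and inositol phosphate accumulation, with a stated time of 75 min, in the presence of a further agent that is not named here; a higher number here means that more compound is needed for the effect, a lower number that less compound is needed. Compound 1 sits in the middle of the three: compound 2 needs a smaller amount, compound 3 a much larger one, and both gaps lie beyond the usual scatter of this assay.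

Compound 4, `Cc1nn(-c2ncnc3nc[nH]c23)c2c1C(C(=O)Nc1ccccc1)CC(=O)N2`, is not yet measured. It differs from compound 1 in one place: phenylcarbamoyl in place of 4-isopropoxyphenyl on a saturated ring carbon. Compound 2 shows that an amide-bearing side chain on the shared core can give a low number in this assay, so no large loss is expected. The step from compound 1 to compound 4 is expected to be small, a 1.7-fold higher number from compound 1 to compound 4 (0.22 log units; within the scatter), and within or near the scatter. Compound 4 is estimated at 30 nM, in a range from 8 nM to 120 nM.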

Compound 4, half-maximal effective concentration: 10 nM
Compound 4: the middle estimate sits 3.0-fold (0.48 log units) above what was measured, within the range that was stated.
By their numbers in this assay, from the lowest: compounds 2, 4 and 1 (each within the scatter of the next, the first and the last beyond it); then compound 3.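

Phenylcarbamoyl in place of 4-isopropoxyphenyl on this saturated ring carbon gives a 1.8-fold lower number from compound 1 to compound 4 (0.26 log units; within the scatter) in this assay, so the two groups cannot be told apart here. This position therefore accepts an amide-linked phenyl ring as well as a directly attached aryl group, on a core where compound 2 had already shown that a different amide side chain can give a low number. Nothing available explains this result.

The compounds shown leave open how this carbon responds to a group without a phenyl ring, such as an amine or a carboxylic acid. They also leave open whether a longer chain on the amide nitrogen would be accepted.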